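The source may hold more compounds than are shown below. What is called first, only, known or untested is meant among the compounds shown, and "the series" means these compounds.

Series notes. In a functional assay on SH-SY5Y cells (Homo sapiens) for antagonist activity, read by cAMP accumulation (a lower number here means a less potent compound, a higher number a more potent compound, by a factor of ten per unit of this negative logarithm), compound 1 (`CCCCCCOc1ccc(Cc2ccc(NC3=NCCN3)cc2)cc1`) gives 8.2, compound 2 (`COCCOc1ccc(Cc2ccc(NC3=NCCN3)cc2)cc1`) gives 8 and compound 3 (`c1cc(NC2=NCCN2)ccc1Cc1ccc(OC2CCCCC2)cc1`) gives 8.6. Compound 1 thus stands within the scatter of compound 2 and clearly under compound 3, the most potent of the three.

Compound 4 (`c1cc(NC2=NCCN2)ccc1Cc1ccc(OCC2CCOCC2)cc1`) is still unmeasured. Its difference from compound 1 is oxan-4-yl in place of pentyl on a saturated chain carbon bound to an oxygen on an aromatic ring.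

For the measured compounds named here, no measured step makes this exact change, but two bear on it. Replacing butyl with methoxy gives a number 0.20 log units lower from compound 1 to compound 2 (within the scatter). Replacing hexyl with cyclohexyl gives a number 0.40 log units higher from compound 1 to compound 3 (beyond the scatter), a modest step. Compound 4 carries a ring, as compound 3 does, and a chain oxygen, as compound 2 does, although its ring oxygen sits differently. The comparison a number 0.60 log units higher from compound 2 to compound 3 (beyond the scatter) shows the gap between those two precedents. The two steps point in opposite directions, so only a slight rise is expected, with nothing beyond the scatter. The expected change is a number 0.10 log units higher from compound 1 to compound 4 (within the scatter). The estimated value for compound 4 is 8.3, with an expected range from 7.9 to 8.7.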

Compound 4, negative logarithm of the antagonist equilibrium constant: 8.5
The estimate for compound 4 lay 0.20 log units below the measured number; the range from low to high includes it.
By their numbers in this assay, from the lowest: compounds 2, 1, 4 and 3 (each within the scatter of the next, the first and the last beyond it).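

Working from a number 0.30 log units higher from compound 1 to compound 4 (within the scatter) in this assay the oxan-4-yl group on a saturated chain carbon bound to an oxygen on an aromatic ring cannot be told apart from the pentyl of the open chain. The reading a number 0.10 log units lower from compound 3 to compound 4 (within the scatter) likewise leaves (oxan-4-yl)methyl and cyclohexyl on that oxygen unseparated, so a ring oxygen is accommodated at this position. Only the reading a number 0.50 log units higher from compound 2 to compound 4 (beyond the scatter) separates the new compound from another, which shows that an ether oxygen in this side group does not by itself go with the number of compound 2.

Nothing measured here explains these numbers.

Still open, as far as these compounds go, is whether piperidin-4-yl, with a ring amine in place of the ring oxygen, reads like oxan-4-yl on the same chain carbon. Also open, from the compounds shown here alone, is how oxan-4-yl behaves set directly on the oxygen on the aromatic ring, without the chain carbon.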